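Dimethyl Substitution on a Benzoxazole Prostanoid Agonist

The source may hold more compounds than are shown below. What is called first, only, known or untested is meant among the compounds shown, and "the series" means these compounds.

Compound 2 `O=C(O)c1csc(SCCN2C(=O)CC[C@@H]2/C=C/[C@@H](O)Cc2cccc(-c3nc4ccccc4o3)c2)n1` is one of two measured compounds in a functional assay on CHO cells for agonist activity at prostaglandin E2 receptor EP4 subtype (Rattus norvegicus), read by cAMP accumulation and immunoassay, with a stated time of 10 min; a lower number here means that less compound is needed, a higher number that more compound is needed for the effect. In this assay compound 2 gives 2.2 nM, the lowest of the two numbers, while its nearest neighbour, compound 1 `O=C(O)CCCSCCN1C(=O)CC[C@@H]1/C=C/[C@@H](O)Cc1cccc(-c2nc3ccccc3s2)c1`, gives 3.2 nM; the gap between these two values lies within the scatter of repeated measurements, so no order between them can be claimed. Compound 3 `Cc1cc(C)c2oc(-c3cccc(C[C@H](O)/C=C/[C@H]4CCC(=O)N4CCSc4nc(C(=O)O)cs4)c3)nc2c1` has not yet been measured. It is related to compound 2 by a single change: 5,7-dimethyl-1,3-benzoxazol-2-yl in place of 1,3-benzoxazol-2-yl on an aromatic carbon. For the measured compounds named here, no step between measured compounds describes the effect of adding methyl groups to this ring system, so there is no direct precedent in the set. Compound 2 shows 2.2 nM and compound 1 shows 3.2 nM, values close together, and this gives no reason to expect a large move. The step of a 1.1-fold lower number from compound 2 to compound 3 (0.04 log units; within the scatter) is expected to be small, within the usual scatter, in either direction. Compound 3 is therefore estimated to give 2 nM in this assay, with a range from 0.6 nM to 7 nM.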

Compound 3, half-maximal effective concentration: 7.7 nM
Estimate against measurement, compound 3: 3.9-fold (0.59 log units) below; the measured number lies above the stated range.
By their numbers in this assay, from the lowest: compounds 2 and 1 (each within the scatter of the next); then compound 3.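

In this assay, the set now holds its first step that can be read at a single place: 5,7-dimethyl-1,3-benzoxazol-2-yl in place of 1,3-benzoxazol-2-yl gives a 3.5-fold higher number from compound 2 to compound 3 (0.54 log units; beyond the scatter), so more compound is needed for the effect. This shows that the benzoxazole part of compound 2 is not indifferent to substitution on its six-membered aromatic ring, although the step is modest, and it comes with the counts of hydrogen-bond donors and acceptors unchanged and no net charge on either group. Nothing measured here accounts for the loss.

Both methyl groups enter in one step, so the compounds shown cannot tell whether one of them or the pair carries the change, or whether the two contribute equally. They also leave open how this place responds to other groups, such as fluorine, chlorine or methoxy, and whether the same dimethyl change would give a step of similar size on another acid side chain, such as the butanoic acid chain of compound 1.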